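An Analog Substituted on the Aromatic Nitrogen, Expected to Remain Inactive

The source may report more compounds than this note shows. Statements on the series, on what has been measured and on what is new or still open speak of the compounds shown alone.

Compound 2 `O=c1cc(CC(O)COCc2ccccc2)[nH]c(=O)[nH]1` is the point of departure. In a functional assay on HepG2 cells (Homo sapiens) for antiproliferative activity, read by MTT assay, with a stated time of 72 h (a lower number here means a stronger inhibitor, a higher number a weaker inhibitor), compound 2 gives > 100000 nM, which is a limit of the assay and not a number. Two further compounds share that position. Compound 3 `Cc1c(CC(O)COCc2ccccc2)[nH]c(=O)[nH]c1=O` gives > 100000 nM in this assay, again a limit. Compound 1 `C[Si](C)(C)CCOCn1c(CC(O)(COCc2ccccc2)COCc2ccccc2)cc(=O)[nH]c1=O` gives > 100000 nM in this assay, also a limit. For the measured compounds named here, the only step between measured compounds that differ in one place, a step that the two limits leave unreadable from compound 2 to compound 3, therefore cannot be read. Across the whole set stands (the limit of > 100000 nM in this assay, at which 3 of the 3 values shown sit).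

Compound 4 `C[Si](C)(C)CCOCn1c(CC(O)COCc2ccccc2)cc(=O)[nH]c1=O` differs from compound 2 by a group of 8 heavy atoms (6 carbon, 1 oxygen, 1 silicon; no ring) in place of a hydrogen atom, on an aromatic nitrogen. Going by the values given here, no measured step matches this change directly. The nearest pointer is compound 1, which carries the same silicon-containing group on the aromatic nitrogen and, with its value already given, stays at the limit. Among the compounds with values here, because the limit of > 100000 nM in this assay, at which 3 of the 3 values shown sit, leaves no measured range in which a change could show, no step in this assay beyond the scatter is expected in either direction. Compound 4 is therefore expected to give about 150000 nM in this assay, within 50000 nM to 500000 nM, and most probably to be reported once more only as a limit. The expected step is a step that the limit leaves unreadable from compound 2 to compound 4, which amounts to no step beyond the scatter.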

Compound 4, half-maximal inhibitory concentration: > 100000 nM
Compound 4: a limit, no number; the forecaster's own chance of this, stated with the estimate: 85%; the middle value lies beyond the limit too.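

In this assay compound 4 gives > 100000 nM, again a limit and not a number. The steps to compound 4 from compound 2 and from compound 1 cannot be read because every value remains at the same limit: the limit of > 100000 nM in this assay, at which 4 of the 4 values shown sit. The compounds shown leave open which structural change, if any, would bring a value within the measurable range of this assay.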